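Methyl on the Phenolic Oxygen of Compound 3

This account rests on a few compounds, and the source may have more. Where it says the series, first, only, none or still open, it means among the compounds named here.

Measured compounds:
compound 1 `COc1ccc(-c2nc3cc(F)ccc3s2)cc1F` gives 13700 nM in a functional assay on HCC 2998 cells (Homo sapiens) for antiproliferative activity; a lower number here means a stronger inhibitor of growth, a higher number a weaker inhibitor of growth;
compound 2 `COc1ccc(-c2nc3cc(F)ccc3s2)cc1Cl` gives 2500 nM;
compound 3 `Oc1ccc(-c2nc3cc(F)ccc3s2)cc1O` gives 1640 nM.

Compound 3 gives the lowest of the three numbers, though its gap to compound 2 lies within the scatter, while its gap to compound 1 lies beyond it. Compound 4 `COc1ccc(-c2nc3cc(F)ccc3s2)cc1O` differs from compound 3 by methyl in place of hydrogen on an oxygen on an aromatic ring. Within the data shown here, the only measured step, a 5.5-fold lower number from compound 1 to compound 2 (0.74 log units; beyond the scatter), concerns a different change and does not bear on this one; compounds 1 and 2, which carry a methoxy group, differ from compound 3 in two places at once, so their values offer no single step. Among the measured compounds shown here, with no direct precedent, compound 4 is expected to stay near compound 3, and the estimated step of a 1.3-fold higher number from compound 3 to compound 4 (0.13 log units; within the scatter) is small. Compound 4 is estimated at 2200 nM, within 700 nM to 7000 nM.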

Compound 4, concentration for 50% growth inhibition: 7600 nM
For compound 4 the middle estimate is 3.5-fold (0.54 log units) below the measured one; measured number outside the range, above it.
By their numbers in this assay, from the lowest: compounds 3 and 2 (each within the scatter of the next); then compounds 4 and 1 (each within the scatter of the next).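

In this assay methyl in place of hydrogen on this oxygen is not a silent change, giving a 4.6-fold higher number from compound 3 to compound 4 (0.67 log units; beyond the scatter). With the methoxy group held constant, hydroxy in place of chloro on the aromatic carbon gives a 3.0-fold higher number from compound 2 to compound 4 (0.48 log units; beyond the scatter), so chloro retains an edge over hydroxy here. Hydroxy in place of fluoro gives a 1.8-fold lower number from compound 1 to compound 4 (0.26 log units; within the scatter), which leaves those two groups unseparated. Nothing shown here accounts for these steps. As far as these compounds go, whether an ethyl group on this oxygen, or an amine in place of the hydroxy, would follow the same course remains open.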